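The source may hold more compounds than are shown below. What is called first, only, known or untested is meant among the compounds shown, and "the series" means these compounds.

Measured compounds in a functional assay on HEK293T cells for agonist activity at histamine H2 receptor (Homo sapiens), read by beta-arrestin recruitment; on this read-out lower numbers stand for smaller maximal responses and higher numbers for larger maximal responses:
- compound 1 `CCCCCCNC(=O)/N=C(\N)NCCCc1sc(N)nc1C` gives 0.28
- compound 2 `Cc1nc(N)sc1CCCN/C(N)=N/C(=O)NC1CCCCC1` gives 0.43

Compound 2 stands highest of the two numbers; its nearest neighbour is compound 1, and the step a number 0.15 higher from compound 1 to compound 2 (beyond the scatter) lies beyond the scatter. The next compound, compound 3 `Cc1nc(N)sc1CCCN/C(N)=N/C(=O)NC(C)c1ccco1`, differs from compound 2 in one place: 1-(furan-2-yl)ethyl in place of cyclohexyl on an amide-type nitrogen. Among the compounds with values here, no measured step swaps a group of this kind; the only step on this nitrogen, a number 0.15 higher from compound 1 to compound 2 (beyond the scatter), shows that exchanging one carbon group for another there can move the read-out modestly, yet it gives no direction for an aromatic group in place of a saturated ring. The expectation is therefore a small step of a number 0.030 lower from compound 2 to compound 3 (within the scatter), within the scatter, with wide uncertainty in either direction. Compound 3 is estimated at 0.4, expected between 0.22 and 0.6.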

Compound 3, intrinsic activity: the largest response reached, as a fraction of the reference agonist's: 0.25
The estimate for compound 3 lay 0.15 above the measured number; the measured number falls inside the stated range.
By their numbers in this assay, from the lowest: compounds 3 and 1 (each within the scatter of the next); then compound 2.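

Within the data shown here, replacing cyclohexyl with 1-(furan-2-yl)ethyl on the amide-type nitrogen lowers the maximal response in this assay (a number 0.18 lower from compound 2 to compound 3 (beyond the scatter)), the first change at this position to bring in a five-membered aromatic ring with 1 hetero atom. Set against hexyl, the same group gives no separable change (a number 0.030 lower from compound 1 to compound 3 (within the scatter)), so among these three groups only cyclohexyl stands apart, while hexyl and 1-(furan-2-yl)ethyl cannot be ordered. Nothing available explains the difference between these groups.

Whether the furan ring or the ethyl part of 1-(furan-2-yl)ethyl accounts for the step stays open, as does the read-out with furan-2-ylmethyl or phenyl on the amide-type nitrogen. Also open, as far as these compounds go, is whether a smaller saturated ring such as cyclopentyl keeps the level of compound 2.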